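Trimming a methoxy from the aryl ring of compound 1

The source may hold more compounds than are shown below. What is called first, only, known or untested is meant among the compounds shown, and "the series" means these compounds.

Measured compounds:
compound 1 `COc1cccc(-n2cc(COc3ccc(/C=C/C(C)=O)cc3OC)nn2)c1`: 1800 nM
compound 2 `CCOC(=O)c1ccc(-n2cc(COc3ccc(/C=C/C(C)=O)cc3OC)nn2)cc1`: > 100000 nM

Of the compounds shown here, two have been measured in a functional assay on MCF7 cells (Homo sapiens) for antiproliferative activity, read by MTT assay, with a stated time of 48 h; a lower number here means a stronger inhibitor, a higher number a weaker inhibitor. Going by the values given here, compound 1 gives 1800 nM, the only numerical value available. For compound 2 the result is a limit rather than a number, > 100000 nM; this is shown as the limit of > 100000 nM in this assay, at which 1 of the 2 values shown sits. So compound 1 holds the one measured number, and no step between measured compounds is available to gauge how changes on the aryl ring move the result.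

The unmeasured compound 3 `COc1cc(/C=C/C(C)=O)ccc1OCc1cn(-c2ccccc2)nn1` differs from compound 1 in one place: hydrogen in place of methoxy on an aromatic carbon. The change sits meta to a large group on a six-membered aromatic ring of carbon only, and the shared core is otherwise untouched.

Among the compounds with values here, with no measured step to lean on, the expectation for this change is modest. Removing a methoxy of this kind is expected to move this assay by a step no larger than the scatter, with perhaps a slight loss, giving an expected 1.4-fold higher number from compound 1 to compound 3 (0.14 log units; within the scatter). Compound 3 is therefore estimated at 2500 nM, within a range from 900 nM to 7000 nM.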

Compound 3, half-maximal inhibitory concentration: > 100000 nM
Compound 3 was reported as a limit; the forecaster's own chance of this, stated with the estimate: 10%; middle value at least 40-fold (1.60 log units) from the limit.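

Going by these compounds alone, replacing the methoxy with a bare hydrogen on this aromatic ring gives an at least 55-fold higher number from compound 1 to compound 3 (1.74 log units; beyond the scatter) in this assay, the first readable step at this place, and it shows that losing just 2 heavy atoms here can take the series from a measurable number to no number at all. The value of compound 3, > 100000 nM, is a limit and not a number. Only compound 1 now gives a number, and the step from compound 2 to compound 3 cannot be read, with both compounds at one shared limit: the limit of > 100000 nM in this assay, at which 2 of the 3 values shown sit.

On these data alone, what remains open is whether the methoxy itself is needed or whether another small group at this place, such as a hydroxyl, a fluorine, an amine or a methyl, would keep a measurable value. As far as these compounds go, it is also open whether a longer chain, such as ethoxy, would do the same here, and whether a methoxy elsewhere on this ring would give a value close to that of compound 1.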